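A few compounds are considered here, and "the series" means these few. Any claim that something is new, unique, unknown or untested is made for them only; others in the source may bear on it.

Two cyclic peroxides carrying a propanoic acid side chain were examined in a functional assay on HCT-15 cells (Homo sapiens) for inhibition; a lower number here means a stronger inhibitor of growth, a higher number a weaker inhibitor of growth. Compound 1, `C=C1CCCC(C)(C)C1CC[C@]1(C)CC[C@@H]([C@@H](C)C(=O)O)OO1`, keeps only a single carbocycle beside the peroxide ring. In this assay compound 1 reaches only the limit of > 10000 nM, so no number is known for it. Compound 2, `C=C1CCC[C@H]2[C@](C)(CC[C@]3(C)CC[C@@H]([C@@H](C)C(=O)O)OO3)[C@@H](C)CC[C@]12C`, carries a fused bicyclic carbocycle in its place, and in this assay compound 2 gives 1160 nM. Among the numbers shown, compound 2 holds the only measured value; the other result is a limit, as noted in the limit of > 10000 nM in this assay, at which 1 of the 2 values shown sits. For the measured compounds named here, no step between measured compounds that differ in one place is available, so the effect of the change to compound 3 must be judged from the structures alone.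

Compound 3 is `C=C1CCC[C@H]2[C@](C)(CC[C@]3(C)CC[C@H]([C@@H](C)C(=O)O)OO3)[C@@H](C)CC[C@]12C`. Its relation to compound 2 is the two compounds have the same atoms and bonds and differ only in configuration as drawn: 1 of 7 stereo elements differ; a stereocentre at a saturated ring carbon is drawn S in compound 2 and R in compound 3. Since compound 2 and compound 3 share every atom and bond, the step from compound 2 to compound 3 is expected to be modest, plausibly a weakening that is estimated as a 2.2-fold higher number from compound 2 to compound 3 (0.33 log units; beyond the scatter) in this assay. Compound 3 is therefore expected to give about 2500 nM in this assay, with a range from 700 nM to 9000 nM.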

Compound 3, concentration for 50% growth inhibition: 1890 nM
Beside the measured number, compound 3's estimate is 1.3-fold (0.12 log units) above it; measured number inside the range.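

In this assay, the stereocentre at a saturated ring carbon, drawn S in compound 2 and R in compound 3, can now be judged directly, and the result is a 1.6-fold higher number from compound 2 to compound 3 (0.21 log units; within the scatter). The earlier compounds shown here offered no such single-place comparison, and this pair shows that the drawn configuration at this one carbon does not separate the two compounds in this read-out, with nothing else varying between them: the fact that compounds 2 and 3 differ only in the configuration as drawn. For the compounds shown here, no step to compound 1 can be read, as its result remains a limit and not a number: the limit of > 10000 nM in this assay, at which 1 of the 3 values shown sits.

As far as these compounds go, the pair tests only 1 of the 7 stereo elements, so it remains open whether a change of configuration at any of the others would separate compounds in the same way, and a single pair cannot show whether this result would hold on another carbocycle. It also leaves open how the series would respond if the carboxylic acid of the side chain gave way to a methyl ester or an amide, since every compound shown carries the acid.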